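The source may report more compounds than this note shows. Statements on the series, on what has been measured and on what is new or still open speak of the compounds shown alone.

Measured compounds:
compound 1 `N=C(N)N/N=C(/C=C/c1ccc(F)cc1)c1ccccc1` — 2500 nM
compound 2 `N=C(N)N/N=C(/C=C/c1cccc(F)c1)c1ccccc1` — 16000 nM

In a functional assay on MCF7 cells (Homo sapiens) for antiproliferative activity, read by MTT assay, with a stated time of 48 h (on this read-out lower numbers stand for stronger inhibition and higher numbers for weaker inhibition), compound 1 gives 2500 nM and holds the lowest number of the two; compound 2 gives 16000 nM, the step being a 6.4-fold higher number from compound 1 to compound 2 (0.81 log units; beyond the scatter). Compound 3 `N=C(N)N/N=C(/C=C/c1ccccc1Br)c1ccccc1` is not yet measured. Its change from compound 1 is 2-bromophenyl in place of 4-fluorophenyl on a double-bonded chain carbon bound to a double-bonded chain carbon. Among the compounds with values here, only the step from compound 1 to compound 2 bears on this: it shows that moving the halogen away from the 4-position raised the number in this assay by a modest amount. Going by these compounds, a bromine at the 2-position is untested, so for compound 3 the writer expects a step of a 3.2-fold higher number from compound 1 to compound 3 (0.51 log units; beyond the scatter), toward a higher number, with wide uncertainty. Compound 3 is thus estimated at 8000 nM, ranging from 2500 nM to 25000 nM.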

Compound 3, half-maximal inhibitory concentration: 4200 nM
For compound 3 the middle estimate is 1.9-fold (0.28 log units) above the measured one; the range from low to high includes it.
By their numbers in this assay, from the lowest: compounds 1 and 3 (each within the scatter of the next); then compound 2.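

In this assay, 2-bromophenyl on a double-bonded chain carbon bound to a double-bonded chain carbon cannot be told apart from 4-fluorophenyl, with a 1.7-fold higher number from compound 1 to compound 3 (0.23 log units; within the scatter). Against 3-fluorophenyl it stands clearly apart, with a 3.8-fold lower number from compound 2 to compound 3 (0.58 log units; beyond the scatter), which leaves compound 2 as the only one of the three separated from the others. No evidence on hand bears on this result. Going by these compounds, this change swaps the halogen and moves it at once, so the share of each stays open. A 2-fluorophenyl, a 4-bromophenyl or an aminophenyl group would help to separate them.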